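The source may hold more compounds than are shown below. What is called first, only, known or untested is meant among the compounds shown, and "the series" means these compounds.

Measured in a functional assay on SW480 cells (Homo sapiens) for inhibition; a lower number here means a stronger inhibitor, a higher number a weaker inhibitor:
- compound 1 `CN[C@H](C#Cc1c(F)ccc2c1/C(=C/c1[nH]ccc1OC)C(=O)N2)CO`: 100 nM
- compound 2 `COc1cc[nH]c1/C=C1\C(=O)Nc2ccc(F)c(C#C[C@@H](N)[C@@H](C)O)c21`: 210 nM

Compound 2 stands at the higher of the two numbers, 210 nM, which makes it the weaker inhibitor of the pair in this assay. Still unmeasured is compound 3 `COc1cc[nH]c1/C=C1\C(=O)Nc2ccc(F)c(C#C[C@@H]3C[C@@H](O)CN3)c21`, and the change leading to it is 4-hydroxypyrrolidin-2-yl in place of 1-amino-2-hydroxypropyl on a triple-bonded carbon. The open 1-amino-2-hydroxypropyl gives way to a group with one five-membered non-aromatic ring, while the counts of hydrogen-bond donors and acceptors stay the same.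

Among the compounds with values here, one measured step bears on this, and it concerns the same triple-bonded carbon: a 2.1-fold higher number from compound 1 to compound 2 (0.32 log units; beyond the scatter). That step is modest, so a change of similar size is the best available guide, and no large move is expected. The direction is poorly settled by a single step. A slight lean towards a lower number is expected, since compound 1 at 100 nM is the only other reference point. The expected move is a 1.4-fold lower number from compound 2 to compound 3 (0.15 log units; within the scatter). For compound 3 the estimate is 150 nM, with an expected range of 50 nM to 450 nM.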

Compound 3, half-maximal inhibitory concentration: 44 nM
Estimate against measurement, compound 3: 3.4-fold (0.53 log units) above, outside the stated range (below it).
By their numbers in this assay, from the lowest: compound 3; then compound 1; then compound 2.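

In this assay the triple-bonded carbon takes the ring of 4-hydroxypyrrolidin-2-yl in place of the open 1-amino-2-hydroxypropyl, and the number falls (a 4.8-fold lower number from compound 2 to compound 3 (0.68 log units; beyond the scatter)) while the counts of hydrogen-bond donors and acceptors stay the same. The ring also compares favourably with the open 2-hydroxy-1-(methylamino)ethyl (a 2.3-fold lower number from compound 1 to compound 3 (0.36 log units; beyond the scatter)), so with both steps beyond the scatter, compound 3 is the strongest inhibitor of the three, and the position responds to the form of the group and not only to those counts. No supporting data are available to explain either step.

The compounds shown leave open whether the gain belongs to the ring itself or to the hydroxyl on it, a question that a plain pyrrolidin-2-yl, a 5-hydroxypiperidin-2-yl or a 4-hydroxy-1-methylpyrrolidin-2-yl would help to separate. The role of the two defined stereocentres also remains open, since the series shown holds only one arrangement of the 4-hydroxypyrrolidin-2-yl group.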